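Benzylsulfanyl Enones Against DU-145 Cells

A few compounds are considered here, and "the series" means these few. Any claim that something is new, unique, unknown or untested is made for them only; others in the source may bear on it.

The measured compounds are:
Compound 1, `O=C(/C(=C\c1ccc(Cl)cc1)SCc1ccccc1Cl)c1ccc(Cl)cc1`, in a functional assay on DU-145 cells (Homo sapiens) for inhibition, read by trypan blue exclusion, with a stated time of 96 h (on this read-out higher numbers stand for weaker inhibition of growth and lower numbers for stronger inhibition of growth), compound 1 gives 12000 nM.
Compound 3, `Cc1ccc(CS/C(=C/c2ccc(Cl)cc2)C(=O)c2ccc(Cl)cc2)cc1`, in this assay compound 3 gives 10000 nM.
Compound 2, `O=C(O)c1ccc(C(=O)/C(=C\c2ccc(F)c([N+](=O)[O-])c2)SCc2ccccc2Cl)cc1`, in this assay compound 2 gives 1000 nM.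

Compound 1 and compound 3 share one core and differ in a single place: 4-methylphenyl in place of 2-chlorophenyl on a saturated chain carbon bound to a sulfur. The step is a 1.2-fold lower number from compound 1 to compound 3 (0.08 log units; within the scatter), so the two values cannot be told apart on this read-out. Compound 2 rests on a different core, and the difference between the two cores is not broken down here; what the numbers show is that compound 2 stands beyond the scatter from both compound 1 and compound 3.

Compound 4, `Cc1ccc(CS/C(=C/c2ccc(F)c([N+](=O)[O-])c2)C(=O)c2ccc(C(=O)O)cc2)cc1`, is not yet measured. It is related to compound 2 by the same change that leads from compound 1 to compound 3: 4-methylphenyl in place of 2-chlorophenyl on a saturated chain carbon bound to a sulfur. Among the measured compounds shown here, since the one measured instance of this change, from compound 1 to compound 3, stayed within the scatter, the step from compound 2 to compound 4 is expected to be small as well, at about a 1.2-fold lower number from compound 2 to compound 4 (0.07 log units; within the scatter), resting on the step of a 1.2-fold lower number from compound 1 to compound 3 (0.08 log units; within the scatter) and the value of compound 2, 1000 nM. Compound 4 is therefore estimated at 850 nM, with the range from 300 nM to 2500 nM covering the usual spread of such measurements around that expectation.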

Compound 4, concentration for 50% growth inhibition: 1000 nM
Beside the measured number, compound 4's estimate is 1.2-fold (0.07 log units) below it, and the stated range covers the measured number.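

In this assay, putting 4-methylphenyl in place of 2-chlorophenyl on a saturated chain carbon bound to a sulfur gives no change at the digits printed from compound 2 to compound 4 (within the scatter). This agrees with the earlier instance of the same change, and the two steps cannot be told apart on this read-out: the same change on two cores in this assay, a 1.2-fold lower number (0.08 log units; within the scatter) from compound 1 to compound 3 and no change at the digits printed (within the scatter) from compound 2 to compound 4, 1.2-fold (0.08 log units) apart, within the scatter of two such steps

So on the two cores shown, this exchange of one benzyl group for the other has no effect that the read-out can resolve, and the two instances give the same answer. Among the compounds shown here, that is all the pair of steps shows: it rests on only two cores, one cell line and one read-out, and it does not establish that the change would stay equally silent on any other core, nor does it explain why it is silent here.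

The compounds shown leave open how far this tolerance extends, as both groups compared at this place are substituted phenyl rings carried on the same saturated chain carbon. How an amine or a longer chain in that place would fare in this assay, on either core, remains an open question.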